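Replacing Fluoro with Isopropoxy on a Shared Core

The compounds below may be only part of what the source reports. "The series", "measured", "known", "first", "only" and "open" are said of these compounds alone.

Compound 1, `COc1ccc(C2=C(c3cc(OC)c(OC)c(OC)c3)C(=O)C(OC(C)=O)C2)cc1F`: 39.5 ug/mL
Compound 2, `COC(=O)c1cc(C2=C(c3cc(OC)c(OC)c(OC)c3)C(=O)CC2O[SiH2]C(C)(C)C)ccc1OC`: > 100 ug/mL
Compound 3, `COCOc1cc(C2=C(c3cc(OC)c(OC)c(OC)c3)C(=O)CC2O[SiH2]C(C)(C)C)ccc1OC`: 50 ug/mL

In an ADME assay on MIA PaCa-2 cells (Homo sapiens) for cytotoxicity, read by MTT assay, with a stated time of 72 h (on this read-out higher numbers stand for weaker inhibition and lower numbers for stronger inhibition), compound 1 gives 39.5 ug/mL, the lowest of the two numbers reported, with compound 3 at 50 ug/mL lying within the scatter of it. For compound 2 only a limit is known, (the limit of > 100 ug/mL in this assay, at which 1 of the 3 values shown sits). Going by the values given here, the one measured step, an at least 2.0-fold lower number from compound 2 to compound 3 (0.30 log units; that floor lies within the scatter), concerns a different change on the aromatic carbon and does not reach the floor of confidence. Compound 4, `COc1ccc(C2=C(c3cc(OC)c(OC)c(OC)c3)C(=O)C(OC(C)=O)C2)cc1OC(C)C`, differs from compound 1 by isopropoxy in place of fluoro on an aromatic carbon. Among the compounds with values here, no measured step bears on this exchange, so the expectation is a step of about a 1.1-fold higher number from compound 1 to compound 4 (0.06 log units; within the scatter), not beyond the scatter. Compound 4 is therefore estimated at 45 ug/mL, within 18 ug/mL to 100 ug/mL.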

Compound 4, half-maximal inhibitory concentration: > 100 ug/mL
Compound 4 gave a limit, no number (the forecaster's own chance of this, stated with the estimate: 20%); middle value at least 2.2-fold (0.34 log units) away from the limit.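

At this position, ortho to a methoxy group, isopropoxy in place of fluoro brings an at least 2.5-fold higher number from compound 1 to compound 4 (0.40 log units; beyond the scatter) in this assay, the only step shown that passes the scatter. Compound 4 is known only as a limit, a place it shares with compound 2: the limit of > 100 ug/mL in this assay, at which 2 of the 4 values shown sit. As far as these compounds go, how large the step truly is therefore stays open, and so does where along the series from fluoro to isopropoxy the number begins to rise. Whether a hydroxy, an ethoxy or an amine at this position would stay near compound 1 is also left open.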